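This account rests on a few compounds, and the source may have more. Where it says the series, first, only, none or still open, it means among the compounds named here.

In a functional assay on MDA-MB-231 cells (Homo sapiens) for cytotoxicity, read by MTT assay (on this read-out higher numbers stand for weaker inhibition and lower numbers for stronger inhibition), compound 1 `Oc1cc(O)cc(-c2cn(-c3ccc(OC(F)(F)F)cc3)nn2)c1` gives only a limit of > 10000 nM. Compound 2 `COc1ccc(-c2cn(-c3ccc(OC)c(OC)c3)nn2)cc1O` also gives only a limit, > 100 nM. Compound 3 `COc1ccc(-c2cn(-c3ccc(OC)c(O)c3)nn2)cc1O` likewise returns only a limit, > 10000 nM. Compound 3 thus shares the limit of > 10000 nM in this assay, at which 2 of the 3 values shown sit, with compound 1, whereas compound 2 sits at the limit of > 100 nM in this assay, at which 1 of the 3 values shown sits. Within the data shown here, the single measured step, a step that the two limits leave unreadable from compound 2 to compound 3, therefore has no readable size. Compound 4 `COc1ccc(-c2cn(-c3ccc(OC)c(O)c3)nn2)cc1` differs from compound 3 by hydrogen in place of hydroxy on an aromatic carbon. Among the measured compounds shown here, no measured step bears directly on this change, and the one neighbouring step is unreadable, so neither direction nor size can be taken from the data. Since compound 3 already rests at a limit, compound 4 is expected to stay weak, with an expected step that the limit leaves unreadable from compound 3 to compound 4. The estimate for compound 4 is 20000 nM, between 5000 nM and 80000 nM.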

Compound 4, half-maximal inhibitory concentration: > 100 nM
Compound 4: only a limit was reported; the forecaster's own chance of this, stated with the estimate: 70%; the middle value does not contradict the limit.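

Compound 3 and compound 4 each give only a limit in this assay, so the step between them cannot be read. The compounds shown leave open how strongly any of them inhibits in this assay, and whether hydrogen in place of hydroxy changes that at all.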